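This account rests on a few compounds, and the source may have more. Where it says the series, first, only, none or still open, it means among the compounds named here.

Measured compounds:
compound 1, `Cc1ccc(CN2C(=O)S/C(=C\c3ccc(F)cc3)C2=O)cc1`, with 13.5% in a functional assay on the whole organism (plasma) with Mus musculus as the target, with a stated time of 15 days, at a dose of 30 mg/kg by the oral route; on this read-out lower numbers stand for a weaker effect and higher numbers for a stronger effect at the one dose given
compound 2, `COc1ccc(/C=C2\SC(=O)N(Cc3ccc(C)cc3)C2=O)cc1`, with 50.8% in this assay

Compound 1 stands lowest of the two values in this assay. Compound 3, `Cc1ccc(CN2C(=O)S/C(=C\c3ccc(Cl)cc3)C2=O)cc1`, differs from compound 1 by chloro in place of fluoro on an aromatic carbon. Going by the values given here, the one measured step, a number 37.3 percentage points higher from compound 1 to compound 2 (beyond the scatter), concerns a different substituent and so bears only loosely on this change. Among the compounds with values here, with no closer precedent, a modest rise is expected, a number 11.5 percentage points higher from compound 1 to compound 3 (beyond the scatter). Compound 3 is therefore estimated at 25% in this assay, within a range from 5% to 50%.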

Compound 3, a percentage reported as activity, at one dose (the size of the read-out at that dose, not a potency): 22.8%
Compound 3: the middle estimate sits 2.2 percentage points above what was measured; the range from low to high includes it.
By their numbers in this assay, from the lowest: compounds 1 and 3 (each within the scatter of the next); then compound 2.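

In this assay, chloro in place of fluoro on the aromatic carbon gives a number 9.3 percentage points higher from compound 1 to compound 3 (within the scatter), so these two halogens cannot be told apart at this position. Chloro in place of methoxy gives a number 28 percentage points lower from compound 2 to compound 3 (beyond the scatter), which shows that methoxy stands clear of chloro as well as of fluoro among these three compounds. Nothing available explains this difference between the groups. The compounds shown leave open how an amine or a hydroxyl group would read at this position, and whether methoxy's standing extends to a longer ether such as ethoxy.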